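A few compounds are considered here, and "the series" means these few. Any claim that something is new, unique, unknown or untested is made for them only; others in the source may bear on it.

Compound 1, `CC(C)OC(=O)N1CCC(Oc2ncnc3c2CCN3c2ccc(S(C)(=O)=O)nc2)CC1`, gives 251 nM in a functional assay on CHO-K1 cells for agonist activity at Glucose-dependent insulinotropic receptor (Homo sapiens), read by a luciferase reporter, with a stated time of 5 h; a lower number here means that less compound is needed, a higher number that more compound is needed for the effect.
Compound 2, `CC(C)OC(=O)N1CCC(Oc2ncnc3c2CCN3c2ccc(S(C)(=O)=O)c(F)c2)CC1`, gives 158 nM in this assay.

Compound 2 gives the lowest of the two numbers shown in this assay, yet the step of a 1.6-fold lower number from compound 1 to compound 2 (0.20 log units; within the scatter) is within the scatter, so the two compounds cannot be told apart on these numbers. Compound 3, `CC(C)OC(=O)N1CCC(Oc2ncnc3c2CCN3c2ccc([S+]([O-])N(C)C)cc2)CC1`, has not been measured. It differs from compound 2 by a group of 11 heavy atoms (8 carbon, 1 nitrogen, 1 oxygen, 1 sulfur; one six-membered aromatic ring of carbon only) in place of a group of 11 heavy atoms (7 carbon, 2 oxygen, 1 fluorine, 1 sulfur; one six-membered aromatic ring of carbon only), on a nitrogen on an aromatic ring in a ring. Going by the values given here, the only measured step, a 1.6-fold lower number from compound 1 to compound 2 (0.20 log units; within the scatter), concerns a different exchange of groups on that same nitrogen and was within the scatter; no measured step covers the group that enters in compound 3. With that little to go on, a step of modest size is expected, a 2.5-fold higher number from compound 2 to compound 3 (0.40 log units; beyond the scatter), leaning towards a higher number in this assay but not certainly beyond the scatter. Compound 3 is therefore estimated at 400 nM, with a range from 120 nM to 1500 nM.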

Compound 3, half-maximal effective concentration: 501 nM
Compound 3: middle estimate off by 1.3-fold (0.10 log units), on the low side; the measured number falls inside the stated range.
By their numbers in this assay, from the lowest: compounds 2, 1 and 3 (each within the scatter of the next, the first and the last beyond it).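

Going by these compounds alone, on the nitrogen on an aromatic ring, compound 3 supplies the first exchange at this position that lies beyond the scatter: in this assay, the new group in place of 3-fluoro-4-(methylsulfonyl)phenyl gives a 3.2-fold higher number from compound 2 to compound 3 (0.50 log units; beyond the scatter) and is modest in size. Set against 6-(methylsulfonyl)pyridin-3-yl, the same group gives a 2.0-fold higher number from compound 1 to compound 3 (0.30 log units; within the scatter), so compound 3 cannot be told apart from compound 1, and only the exchange from compound 2 separates two compounds in this set. Nothing available gives a reason for either step.

Left open is how a nitrile or a carboxylic acid would read on that aromatic ring in place of the sulfur-bearing part. Also open, going by these compounds, is whether the fluorine alone contributes to the gap between compound 2 and compound 3, as their groups differ in more than that one atom.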